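From 2,4-dichlorophenyl to 4-chloro-2-cyanophenyl

The source may hold more compounds than are shown below. What is called first, only, known or untested is meant among the compounds shown, and "the series" means these compounds.

In an ADME assay on the whole organism (Rattus norvegicus, strain Sprague-Dawley) for pharmacokinetics, read by LC-MS (a lower number here means that more of the compound stays in the plasma, a higher number that more of the compound sits outside the plasma), compound 1 `N#Cc1ccc(S(=O)(=O)[C@H]2CN(S(=O)(=O)c3ccc(Cl)cc3Cl)C[C@@]2(O)CO)cc1` gives 2.3 L/kg and compound 2 `N#Cc1ccc(S(=O)(=O)[C@H]2CN(S(=O)(=O)c3ccc(Cl)cc3Cl)C[C@@]2(O)CO)cc1F` gives 1.2 L/kg as its value. Going by the values given here, these are the only two numbers available, and they lie within the scatter of each other, so compound 1 cannot be set apart from its one neighbour. Compound 3 `N#Cc1ccc(S(=O)(=O)[C@H]2CN(S(=O)(=O)c3ccc(Cl)cc3C#N)C[C@@]2(O)CO)cc1` has not yet been measured. It carries cyano in place of chloro on an aromatic carbon, ortho to a large group and meta to a chloro group cyano in place of chloro on an aromatic carbon and so turns 2,4-dichlorophenyl into 4-chloro-2-cyanophenyl.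

Among the compounds with values here, the one measured step is a 1.9-fold lower number from compound 1 to compound 2 (0.28 log units; within the scatter) and comes from fluoro in place of hydrogen on an aromatic carbon. Within the data shown here, that is a different change at a different place, so it bears on compound 3 only loosely, and no measured pair shows cyano in place of chloro. No step beyond the scatter is therefore expected in this assay for this change. The expected size is a 1.2-fold lower number from compound 1 to compound 3 (0.08 log units; within the scatter) as an estimate, with no firm direction. For compound 3 the estimated value is 1.9 L/kg with an expected range from 1 L/kg to 3.6 L/kg in this assay.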

Compound 3, volume of distribution at steady state: 2.6 L/kg
Compound 3: middle estimate off by 1.4-fold (0.14 log units), on the low side; the measured number falls inside the stated range.
By their numbers in this assay, from the lowest: compounds 2, 1 and 3 (each within the scatter of the next, the first and the last beyond it).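

In this assay, cyano in place of chloro on an aromatic carbon, ortho to a large group and meta to a chloro group, gives a 1.1-fold higher number from compound 1 to compound 3 (0.05 log units; within the scatter). Going by these compounds alone, this is the first reading at this position of the 2,4-dichlorophenyl group, since the earlier pair, compounds 1 and 2, differed at another place. Although cyano brings a hydrogen-bond acceptor that chloro does not have, this single pair stays within the usual scatter, so it shows no measurable step for this change at this position, and nothing measured here offers an explanation for that outcome.

The compounds shown leave open whether a different group at this position, such as an amine, a carboxylic acid or a longer alkyl chain, would give a step beyond the scatter. They also leave open whether cyano in place of chloro would read the same in the fluoro-bearing compound 2, and what would follow from changing the remaining chloro group of the 4-chloro-2-cyanophenyl group.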